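Swapping Chloro for Bromo on Two Related Cores

This account rests on a few compounds, and the source may have more. Where it says the series, first, only, none or still open, it means among the compounds named here.

Compound 1 `O=C1C(=O)N(CN2CCN(c3ccnc4cc(C(F)(F)F)ccc34)CC2)c2cc(Cl)ccc21` and compound 2 `O=C1C(=O)N(CN2CCN(c3ccnc4cc(C(F)(F)F)ccc34)CC2)c2cc(Br)ccc21` share a core and differ only in that (bromo in place of chloro on an aromatic carbon). In a functional assay on MDA-MB-468 cells (Homo sapiens) for cytotoxicity, read by sulforhodamine B assay, with a stated time of 48 h (on this read-out lower numbers stand for stronger inhibition of growth and higher numbers for weaker inhibition of growth), compound 1 gives 26100 nM and compound 2 gives 24800 nM; the step between them is a 1.1-fold lower number from compound 1 to compound 2 (0.02 log units; within the scatter). Compound 3 `NC(=S)N/N=C1\C(=O)Nc2cc(Cl)ccc21` has a different core, and how that core differs from the core of compound 1 is not broken down here. In this assay compound 3 gives 17700 nM, within the scatter of the other two values. Compound 4 `NC(=S)N/N=C1\C(=O)Nc2cc(Br)ccc21` differs from compound 3 only in that (bromo in place of chloro on an aromatic carbon), the same change that separates compound 1 from compound 2. Because the earlier step of a 1.1-fold lower number from compound 1 to compound 2 (0.02 log units; within the scatter) stayed within the scatter, the expected step for compound 4 is a 1.1-fold lower number from compound 3 to compound 4 (0.04 log units; within the scatter). The estimate for compound 4 in this assay is 16000 nM, with a range from 8000 nM to 32000 nM.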

Compound 4, concentration for 50% growth inhibition: 18600 nM
Compound 4: the middle estimate sits 1.2-fold (0.07 log units) below what was measured; low and high end bracket the measured number.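

In this assay, bromo in place of chloro gives a 1.1-fold higher number from compound 3 to compound 4 (0.02 log units; within the scatter), so this swap makes no readable difference on the core of compound 3. Set beside the same swap on the core of compound 1, the two results agree: the same change on two cores in this assay, a 1.1-fold lower number (0.02 log units; within the scatter) from compound 1 to compound 2 and a 1.1-fold higher number (0.02 log units; within the scatter) from compound 3 to compound 4, 1.1-fold (0.04 log units) apart, within the scatter of two such steps This shows only that the swap left the number unchanged within the scatter on both cores; it does not show that the same would hold on any other core, or how a change with a real effect would carry from one core to another.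

The compounds shown leave open whether a different group at this place, such as an amine, a methoxy group or a carboxylic acid, would shift the number on either core.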